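Ethyl for Fluoro on Two Related Cores

This account rests on a few compounds, and the source may have more. Where it says the series, first, only, none or still open, it means among the compounds named here.

Measured so far:
compound 1 `CCc1cccc2c(=O)c(-c3nn[nH]n3)c[nH]c12` gives 0.312 mg/kg.
compound 3 `O=c1c(-c2nn[nH]n2)c[nH]c2c(F)cccc12` gives 0.625 mg/kg.
compound 2 `Fc1cccc2cc(-c3nn[nH]n3)cnc12` gives only a limit, > 10 mg/kg.

In a functional assay on the whole organism (strain Sprague-Dawley) for inhibition, with Rattus norvegicus as the target (a higher number here means that more compound is needed for the effect, a lower number that less compound is needed), compound 3 gives 0.625 mg/kg and compound 1 gives 0.312 mg/kg. The change between them is ethyl in place of fluoro on an aromatic carbon, and it made a step of a 2.0-fold lower number from compound 3 to compound 1 (0.30 log units; within the scatter). Compound 2 sits at the limit (the limit of > 10 mg/kg in this assay, at which 1 of the 3 values shown sits), so no number is known for it. How the core of compound 2 differs from the core of compound 3 is not broken down here. Compound 4 `CCc1cccc2cc(-c3nn[nH]n3)cnc12` carries the same change as before, (ethyl in place of fluoro on an aromatic carbon), on the core of compound 2. For compound 4 the expected step is a number no higher from compound 2 to compound 4 (the limit leaves the size open), which rests on a 2.0-fold lower number from compound 3 to compound 1 (0.30 log units; within the scatter). Since compound 2 gave only a limit, compound 4 is expected near 10 mg/kg, between 3 mg/kg and 30 mg/kg, and may again reach only a limit in this assay.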

Compound 4, minimum effective dose: 2.5 mg/kg
Estimate against measurement, compound 4: 4.0-fold (0.60 log units) above; measured number outside the range, below it.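

In this assay, ethyl in place of fluoro gives an at least 4.0-fold lower number from compound 2 to compound 4 (0.60 log units; beyond the scatter), so on this core less compound is needed with ethyl, while the earlier step on the other core stays within the scatter. As far as these compounds go, compound 2 gives only a limit, > 10 mg/kg, so the true size of the new step remains unknown. The change therefore points the same way or shows no clear difference, but whether its size carries over from one core to the other stays unsettled: the same change on two cores in this assay, a 2.0-fold lower number (0.30 log units; within the scatter) from compound 3 to compound 1 and an at least 4.0-fold lower number (0.60 log units; beyond the scatter) from compound 2 to compound 4; the limit leaves it open whether they differ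

The compounds shown carry only fluoro or ethyl at this place, so what a longer chain such as propyl, or an amine, would do there remains open. From the compounds shown here alone, how the change behaves on any third core also remains open.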